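The source may hold more compounds than are shown below. What is called first, only, known or untested is meant among the compounds shown, and "the series" means these compounds.

In an ADME assay on HaCaT cells (Homo sapiens) for antiproliferative activity, with a stated time of 48 h (a lower number here means a stronger inhibitor, a higher number a weaker inhibitor), compound 1 `CC(=O)c1ccc(-c2ccc(N3CCCC3)nn2)cc1` gives > 25000 nM, a limit of the assay and not a number. Compound 2 `CCN(CC)c1ccc(-c2cccc(Cl)c2)nn1` gives > 25000 nM, which is also a limit. This is the only position shown for either compound: the limit of > 25000 nM in this assay, at which 2 of the 2 values shown sit. Compound 3 `CCN(CC)c1ccc(-c2cccc(C#N)c2)nn1` has cyano in place of chloro on an aromatic carbon, meta to a large group: cyano in place of chloro on an aromatic carbon. Going by the values given here, no measured pair shows the size of such a change in this assay, so no step beyond the usual scatter is expected. The expected change is a step that the limit leaves unreadable from compound 2 to compound 3. For compound 3, the estimated value is 28000 nM, within an expected range of 12000 nM to 50000 nM.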

Compound 3, half-maximal inhibitory concentration: > 25000 nM
Compound 3: only a limit was reported; the forecaster's own chance of this, stated with the estimate: 75%; the middle value lies beyond the limit too.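

Going by these compounds alone, compound 2 and compound 3 both sit at a limit, not a number, so no step between them can be read: the limit of > 25000 nM in this assay, at which 3 of the 3 values shown sit. How cyano and chloro truly compare in this assay remains open among the compounds shown.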